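A Phenyl Group Swap Starting From Compound 3

The source may report more compounds than this note shows. Statements on the series, on what has been measured and on what is new or still open speak of the compounds shown alone.

compound 1 `COc1cc(/C=C/C(=O)c2cccc(-n3cc(-c4ccccc4)[nH]c3=O)c2)ccc1O`: 1910 nM
compound 2 `O=C(/C=C/c1cccc(O)c1)c1cccc(-n2cc(-c3ccccc3)[nH]c2=O)c1`: 1980 nM
compound 3 `O=C(/C=C/c1cccc(O)c1)c1cccc(-n2cc(-c3ccc(Cl)cc3)[nH]c2=O)c1`: 1680 nM

In a functional assay on SF-539 cells (Homo sapiens) for inhibition (a lower number here means a stronger inhibitor of growth, a higher number a weaker inhibitor of growth), compound 3 lies within the usual scatter of both compound 1 and compound 2, so these three cannot be ranked. Compound 4 `COc1cc(/C=C/C(=O)c2cccc(-n3cc(-c4ccc(Cl)cc4)[nH]c3=O)c2)ccc1O` has not been measured. It differs from compound 3 by one swap, 4-hydroxy-3-methoxyphenyl in place of 3-hydroxyphenyl (4-hydroxy-3-methoxyphenyl in place of 3-hydroxyphenyl on a double-bonded chain carbon bound to a double-bonded chain carbon). The same swap, run in reverse and without the chloro, gave a 1.0-fold higher number from compound 1 to compound 2 (0.02 log units; within the scatter). Adding chloro gave a 1.2-fold lower number from compound 2 to compound 3 (0.07 log units; within the scatter). Both steps stay within the scatter, so no real shift is expected here. The estimated step is a 1.0-fold higher number from compound 3 to compound 4 (0.01 log units; within the scatter). For compound 4 the expected value is 1700 nM, with an estimated range from 1000 nM to 2900 nM.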

Compound 4, concentration for 50% growth inhibition: 1780 nM
For compound 4 the middle estimate is 1.0-fold (0.02 log units) below the measured one; the measured number falls inside the stated range.
By their numbers in this assay, from the lowest: compounds 3, 4, 1 and 2 (each within the scatter of the next).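

In this assay, the swap to 4-hydroxy-3-methoxyphenyl with chloro present gives a 1.1-fold higher number from compound 3 to compound 4 (0.03 log units; within the scatter), so this change leaves the number as unmoved with chloro as without it: the same change on two cores in this assay, a 1.0-fold higher number (0.02 log units; within the scatter) from compound 1 to compound 2 and a 1.1-fold lower number (0.03 log units; within the scatter) from compound 4 to compound 3, 1.1-fold (0.04 log units) apart, within the scatter of two such steps

Chloro in place of hydrogen on an aromatic carbon, now read with 4-hydroxy-3-methoxyphenyl in place, gives a 1.1-fold lower number from compound 1 to compound 4 (0.03 log units; within the scatter), again no real shift: the same change on two cores in this assay, a 1.2-fold lower number (0.07 log units; within the scatter) from compound 2 to compound 3 and a 1.1-fold lower number (0.03 log units; within the scatter) from compound 1 to compound 4, 1.1-fold (0.04 log units) apart, within the scatter of two such steps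

Still open, from the compounds shown here alone, is whether a phenyl ring carrying an amine or a carboxylic acid at this place on the chain would move the number beyond the scatter.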